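The source may hold more compounds than are shown below. What is called first, only, known or untested is meant among the compounds shown, and "the series" means these compounds.

Compound 1 `O=S(=O)(c1ccccc1)c1ccc(O)nn1` — 40%
Compound 2 `O=S(=O)(c1ccc(Cl)cc1)c1ccc(O)nn1` — 65%
Compound 3 `O=S(=O)(c1ccc(Cl)c(Cl)c1)c1ccc(O)nn1` — 84%

These three compounds share one core and were all tested in a functional assay on the whole organism for inhibition, with Rattus norvegicus as the target, at a dose of 10 mg/kg; on this read-out higher numbers stand for a stronger effect at the one dose given and lower numbers for a weaker effect. Compound 1 carries no substituent on its outer benzene ring and gives 40%. Compound 2 gives 65%, which places it second highest of the three numbers: compound 3, the nearest, gives 84%, and compound 1 lies furthest below. The two measured steps both add a chloro group: a number 25 percentage points higher from compound 1 to compound 2 (beyond the scatter), and a number 19 percentage points higher from compound 2 to compound 3 (beyond the scatter), each beyond the scatter.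

Compound 4 `O=S(=O)(c1ccc(C(F)(F)F)cc1)c1ccc(O)nn1` differs from compound 2 in one place: trifluoromethyl in place of chloro on an aromatic carbon. For the measured compounds named here, the measured steps show only what adding a chloro group does; no step shows what happens when a chloro group is swapped for a trifluoromethyl group, so their bearing is indirect. Since a substituted ring has in both steps given a higher number than a less substituted one, and compound 4 keeps a substituent at the same place, the number for compound 4 is expected to stay near that of compound 2, with a step of a number 3 percentage points higher from compound 2 to compound 4 (within the scatter) that may well lie within the scatter. The estimate for compound 4 is 68%, expected to fall between 50% and 85%.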

Compound 4, a percentage reported as inhibition, in the whole organism at one dose (the size of the read-out at that dose, not a potency): 44%
Beside the measured number, compound 4's estimate is 24 percentage points above it; the whole stated range lies above it.
By their numbers in this assay, from the lowest: compounds 1 and 4 (each within the scatter of the next); then compound 2; then compound 3.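

In this assay, for the compounds shown here, the earlier steps showed only what adding chloro does, and they left room to think that any substituent at this place would help. The new result rules that out for trifluoromethyl, as the change from chloro to trifluoromethyl, para to a large group, gives a number 21 percentage points lower from compound 2 to compound 4 (beyond the scatter), while the comparison with the unsubstituted ring gives a number 4 percentage points higher from compound 1 to compound 4 (within the scatter). At this place, then, the gain seen with a number 25 percentage points higher from compound 1 to compound 2 (beyond the scatter) belongs to chloro and is not shared by trifluoromethyl, and nothing available here bears on what lies behind this difference.

The compounds shown leave open whether other groups at this place, such as a methoxy group, an amine or a nitrile, would track chloro or trifluoromethyl, so a single swap cannot yet define what this place accepts. They also leave open whether the same swap would cost as much on the ring of compound 3, where a second chloro is present and could change how much the first substituent matters.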